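A few compounds are considered here, and "the series" means these few. Any claim that something is new, unique, unknown or untested is made for them only; others in the source may bear on it.

Measured so far in a functional assay on HepG2 cells (Homo sapiens) for inhibition, read by MTT assay, with a stated time of 48 h; on this read-out higher numbers stand for weaker inhibition and lower numbers for stronger inhibition:
- compound 1, `Fc1ccccc1CSc1nnc(-c2ccncc2)n1-c1ccccc1`, gives > 50000 nM; this value is a limit of the assay and not a number.
- compound 2, `O=C(CSc1nnc(-c2ccncc2)n1-c1ccccc1)N/N=C/c1ccccc1`, gives 18600 nM.

Compound 2 carries the only number shown in this assay; the other value shown is a limit (the limit of > 50000 nM in this assay, at which 1 of the 2 values shown sits), so no ordering of the two against each other beyond what the limit itself says is possible. Going by the values given here, no pair of measured compounds differing in one place is present, and the set therefore contains no measured step to calibrate against.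

The unmeasured compound 3, `O=C(CSc1nnc(-c2ccncc2)n1-c1ccccc1)N/N=C/c1ccc(F)cc1`, differs from compound 2 by fluoro in place of hydrogen on an aromatic carbon. The acylhydrazone linker and the shared core of compound 2 are kept unchanged. Among the compounds with values here, with no measured step of comparable kind in the set, the expected size of the step from compound 2 to compound 3 is a 1.2-fold lower number from compound 2 to compound 3 (0.09 log units; within the scatter), which is within the usual scatter rather than a shift in either direction. Compound 3 is accordingly expected to give 15000 nM in this assay, with a range from 6000 nM to 40000 nM.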

Compound 3, half-maximal inhibitory concentration: 9330 nM
Beside the measured number, compound 3's estimate is 1.6-fold (0.21 log units) above it; low and high end bracket the measured number.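

In this assay, going by these compounds alone, the change from phenyl to 4-fluorophenyl provides the first measured step, at a position para to a large group on the aromatic ring: a 2.0-fold lower number from compound 2 to compound 3 (0.30 log units; within the scatter). Within the data shown here, compound 2 and compound 3 therefore cannot be told apart at this read-out, so fluoro in place of hydrogen at this position is tolerated, with the acylhydrazone linker and the shared core unchanged, and the series now has one measured single-place step as a reference, which the earlier compounds could not supply. Nothing among the data shown bears on the cause of this result.

A single small substituent leaves open whether a larger or differently natured group at the same position, such as methoxy, nitro, a dimethylamino group or a carboxylic acid, would give a step beyond the scatter. Also open, on these data alone, is whether fluoro gives a comparable step at other carbons of this ring, or on the phenyl ring that belongs to the shared core.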